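Halogen swap on the benzyl ring: compound 3 to compound 4

The source may report more compounds than this note shows. Statements on the series, on what has been measured and on what is new or still open speak of the compounds shown alone.

Within the data shown here, compound 3 `Fc1ccc(Cn2nnc3c(Br)cccc32)cc1` gives 15 nM in a functional assay on cells for positive allosteric modulation of metabotropic glutamate receptor 2 (Homo sapiens), read by fluorescence and calcium flux, with a stated time of 30 min (on this read-out higher numbers stand for an effect only at larger amounts of compound and lower numbers for an effect already at smaller amounts), the lowest of the three numbers measured so far. Compound 2 `Brc1cccc2c1nnn2Cc1ccccc1` gives 80 nM in this assay, and compound 1 `Fc1ccccc1-c1ccc(Cn2nnc3ccccc32)cn1` gives 600 nM. Among the measured compounds shown here, the only single-point step within the measured set is a 5.3-fold lower number from compound 2 to compound 3 (0.73 log units; beyond the scatter), a hydrogen exchanged for fluoro on the benzyl ring.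

Compound 4 `Brc1ccc(Cn2nnc3c(Br)cccc32)cc1` differs from compound 3 by bromo in place of fluoro on an aromatic carbon. For the measured compounds named here, no measured step exchanges one halogen for another at this position; the step of a 5.3-fold lower number from compound 2 to compound 3 (0.73 log units; beyond the scatter) concerns the arrival of a halogen where none stood and does not bear directly on a fluoro-to-bromo exchange. Nothing in the measured set therefore supports a step beyond the scatter in either direction in this assay. Compound 4 is expected to give about 15 nM in this assay, with a range of 5 nM to 50 nM. The step this estimate implies is no change at the digits printed from compound 3 to compound 4 (within the scatter), within the scatter.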

Compound 4, half-maximal effective concentration: 14 nM
Estimate against measurement, compound 4: 1.1-fold (0.03 log units) above; the range from low to high includes it.
By their numbers in this assay, from the lowest: compounds 4 and 3 (each within the scatter of the next); then compound 2; then compound 1.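

In this assay, bromo in place of fluoro on this aromatic carbon, para to a large group, gives a 1.1-fold lower number from compound 3 to compound 4 (0.03 log units; within the scatter) and so does not separate the two halogens. Bromo in place of hydrogen gives a 5.7-fold lower number from compound 2 to compound 4 (0.76 log units; beyond the scatter) and, like a 5.3-fold lower number from compound 2 to compound 3 (0.73 log units; beyond the scatter), lies beyond the scatter, so with compound 4 the lower number than compound 2 holds for a second halogen at this place. Nothing measured on hand accounts for this result.

On these data alone, whether the tolerance at this carbon extends beyond fluoro and bromo remains open, as a methoxy group, an amine or a carboxylic acid here could read quite differently. Also open, as far as these compounds go, is whether the same exchanges behave alike at other carbons of this ring.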